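A few compounds are considered here, and "the series" means these few. Any claim that something is new, unique, unknown or untested is made for them only; others in the source may bear on it.

Compound 1 `C=CC(=O)Nc1cccc(Nc2nc(N/N=C(\C)c3ccc(F)cc3F)ncc2Cl)c1` and compound 2 `C=CC(=O)Nc1cccc(Nc2nc(N/N=C(\C)c3ccc(OC)cc3)ncc2Cl)c1` share one core and differ in a single place: 4-methoxyphenyl in place of 2,4-difluorophenyl on a carbon with a double bond to nitrogen. In an ADME assay on HT-29 cells (Homo sapiens) for inhibition, read by MTT assay, with a stated time of 72 h (on this read-out lower numbers stand for stronger inhibition and higher numbers for weaker inhibition), compound 1 gives 4360 nM, and compound 2 gives 4560 nM, so the exchange made a 1.0-fold higher number from compound 1 to compound 2 (0.02 log units; within the scatter). Compound 3 `CN(C)C/C=C/C(=O)Nc1cccc(Nc2nc(N/N=C/c3ccc(F)cc3F)ncc2Cl)c1` gives 2920 nM in this assay, and its value sits within the usual scatter of those of compound 1 and compound 2. How the core of compound 3 differs from the core of compound 1 is not broken down here.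

Compound 4 `COc1ccc(/C=N/Nc2ncc(Cl)c(Nc3cccc(NC(=O)/C=C/CN(C)C)c3)n2)cc1` has not yet been measured. It differs from compound 3 by 4-methoxyphenyl in place of 2,4-difluorophenyl on a carbon with a double bond to nitrogen. Within the data shown here, this is the same kind of change as the one between compound 1 and compound 2, not the same: in compound 1 the carbon with a double bond to nitrogen also carries a saturated chain carbon, whereas in compound 3 its only other neighbour is the double-bonded nitrogen. Resting on a 1.0-fold higher number from compound 1 to compound 2 (0.02 log units; within the scatter), the expected step is a 1.0-fold higher number from compound 3 to compound 4 (0.01 log units; within the scatter). Compound 4 is therefore estimated at 3000 nM in this assay, likely between 1500 nM and 6000 nM.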

Compound 4, half-maximal inhibitory concentration: 4820 nM
Compound 4: the middle estimate sits 1.6-fold (0.21 log units) below what was measured; the measured number falls inside the stated range.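

In this assay the exchange of 2,4-difluorophenyl for 4-methoxyphenyl gives a 1.7-fold higher number from compound 3 to compound 4 (0.22 log units; within the scatter) and so stays within what repeated measurements would scatter over, as it did on the core of compound 1. Set side by side, the two steps do not differ: the same change on two cores in this assay, a 1.0-fold higher number (0.02 log units; within the scatter) from compound 1 to compound 2 and a 1.7-fold higher number (0.22 log units; within the scatter) from compound 3 to compound 4, 1.6-fold (0.20 log units) apart, within the scatter of two such steps. This shows that, for these two pairs, the exchange carried from one core to the other with no difference that can be told from the scatter, but it does not show that the exchange is without effect on every core, and a small dependence on the core could stay hidden inside that scatter.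

The compounds shown leave open whether the same agreement would hold for a ring carrying another group in this place, such as an amine or a carboxylic acid. They also leave open how the exchange would behave on a third core, for example one carrying a longer chain.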